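Series notes: cyano for nitro, compound 2 to compound 4

The compounds below may be only part of what the source reports. "The series", "measured", "known", "first", "only" and "open" are said of these compounds alone.

Measured so far:
Compound 1 `CCc1nc(N)nc(N)c1-c1ccc(NCc2ccc([N+](=O)[O-])cc2)cc1`; in a functional assay on CHOK cells for antagonist activity at growth hormone secretagogue receptor type 1 (Homo sapiens), read by calcium flux (a higher number here means a weaker inhibitor, a lower number a stronger inhibitor), compound 1 gives 23 nM.
Compound 2 `Nc1nc(N)c(-c2ccc(NCc3ccc([N+](=O)[O-])cc3)cc2)c(COCc2ccccc2)n1`; in this assay compound 2 gives 5.8 nM.
Compound 3 `Nc1nc(N)c(-c2ccc(NCc3cc(F)c(S(=O)(=O)C(F)(F)F)c(F)c3)cc2)c(COCc2ccccc2)n1`; in this assay compound 3 gives 85 nM.

Compound 2 holds the lowest number of the three. Within the data shown here, its nearest neighbour is compound 1, the one single-place step in the set: a 4.0-fold lower number from compound 1 to compound 2 (0.60 log units; beyond the scatter). Among the measured compounds shown here, compound 3 differs from compound 2 in more than one place, so no step is computed for it; its higher number is simply noted.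

Compound 4 `N#Cc1ccc(CNc2ccc(-c3c(N)nc(N)nc3COCc3ccccc3)cc2)cc1` differs from compound 2 only by cyano in place of nitro on an aromatic carbon. For the measured compounds named here, no measured step touches this position: the step from compound 1 to compound 2 concerns the other end of the molecule, and nothing in the set swaps one small group for another on the benzyl ring alone. The change is therefore expected to move this assay little, if at all, with the outcome open in either direction. Compound 4 is estimated at 10 nM, range 3 nM to 35 nM, which means an expected step of a 1.7-fold higher number from compound 2 to compound 4 (0.24 log units; within the scatter).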

Compound 4, half-maximal inhibitory concentration: 19 nM
Estimate against measurement, compound 4: 1.9-fold (0.28 log units) below; measured number inside the range.
By their numbers in this assay, from the lowest: compound 2; then compounds 4 and 1 (each within the scatter of the next); then compound 3.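

In this assay the change from 4-nitrobenzyl to 4-cyanobenzyl gives a 3.3-fold higher number from compound 2 to compound 4 (0.52 log units; beyond the scatter), the first single-place step read at this end of the molecule. The position is therefore not silent: with the core and the benzyloxy group unchanged, cyano does not stand in for nitro without a change in the number, and compound 2 stays the lower of the pair. Nothing available accounts for the size or direction of this step.

Still open, on these data alone, is whether an amine, a carboxylic acid or a chlorine on the same aromatic carbon would give a number nearer to that of compound 2 or of compound 4. Also open, as far as these compounds go, is whether cyano in place of nitro moves the number similarly on the core of compound 1.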